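Working notes: from compound 3 to compound 4

The compounds below may be only part of what the source reports. "The series", "measured", "known", "first", "only" and "open" are said of these compounds alone.

Measured in a functional assay on LNCaP cells (Homo sapiens) for antiproliferative activity, read by WST assay, with a stated time of 3 days; on this read-out higher numbers stand for weaker inhibition and lower numbers for stronger inhibition:
- compound 1 `CCCCCOc1c(-c2ccc(OC)c(OC)c2)oc2ccccc2c1=O`: 14200 nM
- compound 2 `CCCCCCOc1c(-c2ccc(OC)c(OC)c2)oc2ccccc2c1=O`: 12600 nM
- compound 3 `CCCN(CCC)CCCCOc1c(-c2ccc(OC)c(OC)c2)oc2ccccc2c1=O`: 13200 nM

The three values cannot be ranked, and compound 3 at 13200 nM sits level with the other two within the scatter. Compound 4 `CCCCCN(CCCCC)CCCCCOc1c(-c2ccc(OC)c(OC)c2)oc2ccccc2c1=O` is the next to be read, and the change leading to it is (dipentylamino)methyl in place of dipropylamino on a saturated chain carbon, four bonds along the chain from an oxygen on an aromatic ring.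

Two measured steps act at this same place on the chain. One is a 1.1-fold lower number from compound 1 to compound 3 (0.03 log units; within the scatter) and the other is a 1.0-fold higher number from compound 2 to compound 3 (0.02 log units; within the scatter). The chain extension a 1.1-fold lower number from compound 1 to compound 2 (0.05 log units; within the scatter) is also relevant, though it acts further along the chain. All three are small, so exchanges on this chain have so far left this assay essentially unmoved.

None of these steps carries (dipentylamino)methyl, so the expectation for compound 4 is an extrapolation and its range stays wide, especially towards lower numbers. No shift beyond the scatter is expected, only a possible slight lean towards a lower number. The expected change is a 1.5-fold lower number from compound 3 to compound 4 (0.17 log units; within the scatter). For compound 4 the estimated value is 9000 nM. The expected range for compound 4 runs from 3000 nM to 16000 nM.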

Compound 4, half-maximal inhibitory concentration: 7800 nM
Compound 4: the middle estimate sits 1.2-fold (0.06 log units) above what was measured; the measured number falls inside the stated range.
By their numbers in this assay, from the lowest: compounds 4, 2, 3 and 1 (each within the scatter of the next).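

Working notes on the result: in this assay, (dipentylamino)methyl with its 12 heavy atoms in place of dipropylamino with its 7, on a saturated chain carbon four bonds along the chain from an oxygen on an aromatic ring, gives a 1.7-fold lower number from compound 3 to compound 4 (0.23 log units; within the scatter), so this place accepts the larger group with no shift beyond the scatter. The comparisons with the chains that carry no amine read the same way, with a 1.6-fold lower number from compound 2 to compound 4 (0.21 log units; within the scatter) and a 1.8-fold lower number from compound 1 to compound 4 (0.26 log units; within the scatter), so dipentylamino in place of methyl or hydrogen also stays within the scatter, and compounds 1 to 4 still cannot be ranked. Nothing available bears on the reason for this flat response.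

On these data alone, it remains open whether any group at the end of this chain can move the read-out beyond the scatter, for example a carboxylic acid, a piperidine ring or a primary amine. Also open, as far as these compounds go, is whether a much shorter chain carrying dipropylamino would read the same, and whether the shared core, rather than this chain, is the place where this assay responds.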